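From 3-hydroxybenzyl to 4-hydroxycyclohexyl on the shared core

This account rests on a few compounds, and the source may have more. Where it says the series, first, only, none or still open, it means among the compounds named here.

In a functional assay on HL-60 cells (Homo sapiens) for inhibition, read by CCK-8 assay, with a stated time of 48 h (a higher number here means a weaker inhibitor, a lower number a stronger inhibitor), compound 1 `O=[N+]([O-])c1ccc(NC(=S)NCCNS(=O)(=O)c2ccc(-c3ccccc3OCc3ccccc3)s2)cc1` reads > 50000 nM, which is a limit of the assay and not a number. Going by the values given here, compound 2 `O=[N+]([O-])c1ccc(NC(=S)NCCNS(=O)(=O)c2ccc(-c3ccccc3OCc3cccc(O)c3)s2)cc1` gives 10800 nM, the only true number so far. Compound 3 `O=[N+]([O-])c1ccc(NC(=S)NCCNS(=O)(=O)c2ccc(-c3ccccc3O[C@H]3CC[C@H](O)CC3)s2)cc1` changes the group on the oxygen: 4-hydroxycyclohexyl in place of 3-hydroxybenzyl on an oxygen on an aromatic ring. The hydroxy stays, but the six-membered aromatic ring of carbon only gives way to a non-aromatic one.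

Among the compounds with values here, the only measured guide is an at least 4.6-fold lower number from compound 1 to compound 2 (0.66 log units; beyond the scatter), which came with a hydroxy in place of hydrogen on an aromatic carbon. Compound 3 also carries a hydroxy, though not on an aromatic carbon, so that step offers only partial guidance. Within the data shown here, no measured step tests the loss of the aromatic ring. The expected step in this assay is therefore modest, and it is a 1.5-fold higher number from compound 2 to compound 3 (0.17 log units; within the scatter), leaning towards a weaker inhibitor. For compound 3 the estimated value is 16000 nM, with an expected range from 6000 nM to 45000 nM.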

Compound 3, half-maximal inhibitory concentration: 11600 nM
For compound 3 the middle estimate is 1.4-fold (0.14 log units) above the measured one; the measured number falls inside the stated range.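

In this assay, the change to 4-hydroxycyclohexyl gives a 1.1-fold higher number from compound 2 to compound 3 (0.03 log units; within the scatter), so on this oxygen a non-aromatic ring carrying a hydroxy reads the same as the aromatic ring carrying one, and the aromatic ring is not needed for the activity seen in compound 2. Set against the benzyl group, the same 4-hydroxycyclohexyl group gives an at least 4.3-fold lower number from compound 1 to compound 3 (0.63 log units; beyond the scatter), making this the second ring with a hydroxy that gives a true number where benzyl does not, although this step changes the ring as well as adding the hydroxy. The size of that step is only a minimum because compound 1 stands at a limit of the assay and not at a number: the limit of > 50000 nM in this assay, at which 1 of the 3 values shown sits.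

Open, on these data alone, is whether plain cyclohexyl on this oxygen would read like compound 1 or like compound 3, which would show how much the hydroxy contributes on the non-aromatic ring. Also open, as far as these compounds go, is whether an amine or a carboxylic acid could take the place of that hydroxy, and whether the other stereoisomer of the 4-hydroxycyclohexyl group would read the same.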